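The source may report more compounds than this note shows. Statements on the series, on what has been measured and on what is new or still open speak of the compounds shown alone.

Measured so far:
- Compound 1 `N#Cc1ccc(NCCNc2ncc(-c3ncc[nH]3)c(-c3ccc(Cl)cc3Cl)n2)nc1`: > 0.5 h
- Compound 2 `Nc1nc(NCCNc2ncc(-c3ncc[nH]3)c(-c3ccc(C(F)(F)F)cc3)n2)ccc1[N+](=O)[O-]`: > 0.5 h

Both entries are limits of the assay and not numbers.

The read-out here is an ADME assay on microsomes from liver (Canis lupus familiaris) for metabolic stability; on this read-out lower numbers stand for a shorter-lived compound and higher numbers for a longer-lived compound. In this assay compound 2 gives > 0.5 h, which is a limit. Compound 1 gives > 0.5 h, which is also a limit. The position of compound 2 is therefore known only as a limit, and the whole picture so far is the limit of > 0.5 h in this assay, at which 2 of the 2 values shown sit. No order between the two compounds can be drawn from this.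

Compound 3 `Nc1nc(NCCNc2ncc(-c3ncc[nH]3)c(-c3cc(F)ccc3Cl)n2)ccc1[N+](=O)[O-]` carries 2-chloro-5-fluorophenyl in place of 4-(trifluoromethyl)phenyl on an aromatic carbon of the shared core (2-chloro-5-fluorophenyl in place of 4-(trifluoromethyl)phenyl on an aromatic carbon).

For the measured compounds named here, no pair of measured compounds differs in one place only, so the data give no size for a change of this kind. No step beyond the usual scatter is expected in this assay, and no direction is favoured. The expected step is a step that the limit leaves unreadable from compound 2 to compound 3.

For compound 3 the estimate is 0.6 h, with an expected range of 0.3 h to 1.2 h.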

Compound 3, half-life: > 0.5 h
Compound 3: no number, only a limit; the forecaster's own chance of this, stated with the estimate: 60%; the middle value lies beyond the limit too.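

No step can be read from compound 2 to compound 3 in this assay, since both entries are limits and not numbers: the limit of > 0.5 h in this assay, at which 3 of the 3 values shown sit.

The compounds shown leave open how long each one actually lasts in this assay, and whether 2-chloro-5-fluorophenyl in place of 4-(trifluoromethyl)phenyl on an aromatic carbon of the shared core shifts the half-life at all.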